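The compounds below may be only part of what the source reports. "The series", "measured", "known", "first", "only" and "open" are said of these compounds alone.

Working notes on the series, step from compound 3 to compound 4.

The series shares one core; compound 1 `COc1cccc(Oc2ccc3c(NCCCNCc4cc(F)ccc4OC)ccnc3c2)c1` carries 3-methoxyphenoxy on the aromatic carbon of that core, compound 2 `COc1ccc(F)cc1CNCCCNc1ccnc2cc(CC(C)C)ccc12` carries isobutyl there, and compound 3 `COc1ccc(F)cc1CNCCCNc1ccnc2cc(Cc3ccccc3)ccc12` carries benzyl. In a physicochemical assay for solubility, with a stated time of 18 h, at pH 7.4 (a lower number here means a less soluble compound, a higher number a more soluble compound), compound 1 gives 14500 nM, compound 2 gives 4200 nM and compound 3 gives 4200 nM. Compound 3 thus sits level with compound 2 and together they form the lowest pair of the three; the step of a 3.5-fold lower number from compound 1 to compound 3 (0.54 log units; beyond the scatter) is beyond the scatter, while the step of no change at the digits printed from compound 2 to compound 3 (within the scatter) is within it.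

Compound 4 `COc1ccc(-c2ccc3c(NCCCNCc4cc(F)ccc4OC)ccnc3c2)cc1` is next: 4-methoxyphenyl in place of benzyl on an aromatic carbon. Among the measured compounds shown here, two measured steps bear on this change. The step of no change at the digits printed from compound 2 to compound 3 (within the scatter) shows that swapping phenyl for isopropyl on the saturated chain carbon left the number unmoved, so the aromatic ring itself carries little here. The step of a 3.5-fold lower number from compound 1 to compound 3 (0.54 log units; beyond the scatter), in which a methoxy-bearing aryl group was lost, shows the only move beyond the scatter in the set, and compound 4 brings a methoxy-bearing aryl group back, now bound directly to the aromatic carbon. Compound 4 is therefore expected to give a modest rise, a 1.5-fold higher number from compound 3 to compound 4 (0.19 log units; within the scatter), so that compound 4 is estimated at 6500 nM, within a range of 2500 nM to 16000 nM.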

Compound 4, solubility: 32000 nM
Compound 4: the middle estimate sits 4.9-fold (0.69 log units) below what was measured; measured number above the stated range.
By their numbers in this assay, from the lowest: compounds 2 and 3 (each within the scatter of the next); then compound 1; then compound 4.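

In this assay this position gives a higher number with 4-methoxyphenyl on the aromatic carbon than with any of the three earlier groups, seen in a 7.6-fold higher number from compound 3 to compound 4 (0.88 log units; beyond the scatter) and in a 7.6-fold higher number from compound 2 to compound 4 (0.88 log units; beyond the scatter) and also in a 2.2-fold higher number from compound 1 to compound 4 (0.34 log units; beyond the scatter). The earlier compounds shown here showed only a fall from 3-methoxyphenoxy to isobutyl or benzyl, whereas the position now also shows room above compound 1, and the two groups holding a methoxy, in compound 1 and compound 4, both stand above the two without one, with no compound of the four going against this. The change from benzyl to 4-methoxyphenyl both joins the ring directly to the aromatic carbon and adds a methoxy oxygen, and no data here give a cause for the rise or separate those two parts.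

The compounds shown leave open whether a plain phenyl ring on this aromatic carbon would stand with compound 4 or with compound 3, which would separate the direct ring attachment from the methoxy. They also leave open how an amine or a carboxylic acid in place of the methoxy on that ring would read in this assay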